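The source may hold more compounds than are shown below. What is called first, only, known or untested is meant among the compounds shown, and "the series" means these compounds.

Compounds measured so far in a functional assay on WI-38 VA13 cells (Homo sapiens) for cytotoxicity; on this read-out lower numbers stand for an effect already at smaller amounts and higher numbers for an effect only at larger amounts of compound:
compound 1, `Cc1ccc(C(=O)Nc2ccc3nc(NC(=O)C4CCCCC4)sc3c2)cc1`: 5.1 ug/mL
compound 2, `O=C(Nc1ccc2nc(NC(=O)C3CCCCC3)sc2c1)c1c(Cl)cccc1Cl`: 0.015 ug/mL
compound 3, `Cc1cc(C(=O)Nc2ccc3nc(NC(=O)C4CCCCC4)sc3c2)c(C)n1C`: > 6.2 ug/mL

Compound 3 stands at the weak end of this set: its entry in this assay is a limit of the assay and not a number, the same limit as in the limit of > 6.2 ug/mL in this assay, at which 1 of the 3 values shown sits. The measured steps show that the acyl group on the carbonyl carbon drives the read-out: a 340-fold lower number from compound 1 to compound 2 (2.53 log units; beyond the scatter), whereas an at least 1.2-fold higher number from compound 1 to compound 3 (0.08 log units; that floor lies within the scatter) and an at least 410-fold higher number from compound 2 to compound 3 (2.61 log units; beyond the scatter). Compound 4, `C=CCOC(=O)Nc1ccc2nc(NC(=O)C3CCCCC3)sc2c1`, is reached from compound 3 by allyloxy in place of 1,2,5-trimethyl-1H-pyrrol-3-yl on a carbonyl carbon. The step from compound 1 to compound 3 shows that replacing one aromatic acyl group by another of similar size need not move the number; only the 2,6-dichlorophenyl group in compound 2 gave a large step. An allyloxy group resembles neither of those cases, so no step beyond the scatter is expected for an at least 1.2-fold lower number from compound 3 to compound 4 (0.09 log units; that floor lies within the scatter), and compound 4 is also likely to return a limit. Compound 4 is therefore estimated at 5 ug/mL, with a range from 1 ug/mL to 25 ug/mL.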

Compound 4, half-maximal effective concentration: 0.58 ug/mL
Compound 4: the middle estimate sits 8.6-fold (0.94 log units) above what was measured, outside the stated range (below it).
By their numbers in this assay, from the lowest: compound 2; then compound 4; then compound 1. At a limit, above all of these: compound 3.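

In this assay, the place on a carbonyl carbon whose other neighbour is an amide-type nitrogen proves able to take a group with no ring and still give a low number, and allyloxy in place of 1,2,5-trimethyl-1H-pyrrol-3-yl gives an at least 10-fold lower number from compound 3 to compound 4 (1.02 log units; beyond the scatter). Allyloxy also differs from 4-methylphenyl, with an 8.8-fold lower number from compound 1 to compound 4 (0.94 log units; beyond the scatter), so among these compounds a lower number does not depend on an aromatic ring at this place, yet 2,6-dichlorophenyl goes against any simple ranking of ringless over ring-bearing groups, with a 39-fold higher number from compound 2 to compound 4 (1.59 log units; beyond the scatter). The entry for compound 3 is a limit of the assay and not a number, so its step gives only a floor: the limit of > 6.2 ug/mL in this assay, at which 1 of the 4 values shown sits.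

The compounds shown leave open whether the number of compound 4 goes with the oxygen on the carbonyl carbon or with the double bond of the allyl chain. An ethoxy group, a propyl chain or a dimethylamino group at this place would separate those two parts, and a 2-chlorophenyl group would ask whether both chlorines of compound 2 are needed for its much lower number.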